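Lengthening the Linker from Compound 3 to Compound 4

The compounds below may be only part of what the source reports. "The series", "measured", "known", "first", "only" and "open" are said of these compounds alone.

Measured so far:
compound 1, `C#CCN(C)Cc1cccc(NC(=O)CCC(=O)NO)c1`: > 10000 nM
compound 2, `C#CCN(C)Cc1cccc(NC(=O)CCCC(=O)NO)c1`: > 10000 nM
compound 3, `C#CCN(C)Cc1cccc(NC(=O)CCCCCC(=O)NO)c1`: 4630 nM

In a functional assay on PC-3 cells (Homo sapiens) for inhibition, read by MTT assay, with a stated time of 48 h (on this read-out higher numbers stand for weaker inhibition of growth and lower numbers for stronger inhibition of growth), compound 1 reaches only the assay limit, > 10000 nM. Compound 2 likewise gives only a limit, > 10000 nM. Within the data shown here, compound 3 is the sole member of the set with a real number, 4630 nM, and therefore stands as the only fixed point on the scale. The step that the two limits leave unreadable from compound 1 to compound 2 cannot be read, since both ends sit at the limit (the limit of > 10000 nM in this assay, at which 2 of the 3 values shown sit). The steps of an at least 2.1-fold lower number from compound 1 to compound 3 (0.33 log units; beyond the scatter) and an at least 2.1-fold lower number from compound 2 to compound 3 (0.33 log units; beyond the scatter) both run toward stronger inhibition of growth as the chain lengthens.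

Compound 4, `C#CCN(C)Cc1cccc(NC(=O)CCCCCCCC(=O)NO)c1`, continues this series: 2-(hydroxycarbamoyl)ethyl in place of hydroxycarbamoyl on a saturated chain carbon, five bonds along the chain from a carbonyl carbon. Given that each readable lengthening so far has lowered the number, the step of a 2.6-fold lower number from compound 3 to compound 4 (0.41 log units; beyond the scatter) is expected to be a modest move in the same direction, though the true size of the earlier steps is hidden by the limit. Compound 4 is therefore estimated at 1800 nM in this assay, within a range of 500 nM to 6500 nM.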

Compound 4, concentration for 50% growth inhibition: 4070 nM
Compound 4: middle estimate off by 2.3-fold (0.35 log units), on the low side; low and high end bracket the measured number.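

In this assay, the further lengthening gives a 1.1-fold lower number from compound 3 to compound 4 (0.06 log units; within the scatter), so the two chains cannot be told apart, and the gain in growth inhibition that the earlier readable steps showed does not carry on at this length. Against the shorter chain, the record still reads an at least 2.4-fold lower number from compound 2 to compound 4 (0.39 log units; beyond the scatter). That step is only a bound, because compound 2 sits at a limit of the assay: the limit of > 10000 nM in this assay, at which 2 of the 4 values shown sit.

Going by these compounds, whether a longer chain than that of compound 4 would hold this level, improve on it or lose it remains open. So does the question of whether a carboxylic acid in place of the hydroxycarbamoyl end, or a secondary amine in place of the tertiary one in the shared core, would change growth inhibition at this chain length.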